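Dipropylamino Gives Way to 3-Methylpiperidin-1-yl

This account rests on a few compounds, and the source may have more. Where it says the series, first, only, none or still open, it means among the compounds named here.

Measured so far in an ADME assay on MT4 cells (Homo sapiens) for cytotoxicity, read by MTT assay, with a stated time of 4 days; on this read-out lower numbers stand for higher toxicity in this test and higher numbers for lower toxicity in this test:
Compound 1 `CCN(CC)c1nc(Cc2c(F)cccc2F)c(C)c(=O)[nH]1`: > 81000 nM (a limit)
Compound 2 `CCCN(CCC)c1nc(Cc2c(F)cccc2F)c(C)c(=O)[nH]1`: > 74000 nM (a limit)
Not yet measured:
Compound 3 `Cc1c(Cc2c(F)cccc2F)nc(N2CCCC(C)C2)[nH]c1=O`

Compound 2 has no exact number in this assay, only the limit > 74000 nM. The change to compound 3 is 3-methylpiperidin-1-yl in place of dipropylamino on an aromatic carbon: 3-methylpiperidin-1-yl takes the place of dipropylamino on an aromatic carbon, between two ring nitrogen atoms. For the measured compounds named here, the one measured step that bears on this is a step that the two limits leave unreadable from compound 1 to compound 2, another change of the amino group at that place. Both its ends are limits, so it offers no size and no direction. No step beyond the scatter is therefore expected in this assay, and another limit is the likeliest report. The expected size is a step that the limit leaves unreadable from compound 2 to compound 3. For compound 3 the estimate is 75000 nM, with an expected range from 30000 nM to 150000 nM.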

Compound 3, half-maximal cytotoxic concentration: > 75000 nM
Compound 3 gave a limit, no number; the forecaster's own chance of this, stated with the estimate: 75%; the middle value lies on the limit itself.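

For the compounds shown here, compound 1, compound 2 and compound 3 all stand only as limits in this assay, and no step among them can be read. The compounds shown leave open whether changing the amino group on the shared core alters the half-maximal cytotoxic concentration at all.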